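A few compounds are considered here, and "the series" means these few. Any claim that something is new, unique, unknown or untested is made for them only; others in the source may bear on it.

Working notes on the series. Compound 1 `CCCNC(=O)c1ccc(-n2cc(CCC(C)C)nn2)cc1O` gives > 20000 nM in a functional assay on RAW264.7 cells (Mus musculus) for inhibition, read by Griess assay, with a stated time of 20 h (a higher number here means a weaker inhibitor, a lower number a stronger inhibitor), as a limit of the assay, not a number. Compound 2 `O=C(c1ccc(-n2cc(-c3ccccc3)nn2)cc1O)N1CCCCC1` gives > 20000 nM in this assay and this too is only a limit. Compound 2 therefore has no measured potency, and the record so far holds only the limit of > 20000 nM in this assay, at which 2 of the 2 values shown sit, for the series.

The next compound is compound 3 `CC(C)CCc1cn(-c2ccc(C(=O)N3CCCCC3)c(O)c2)nn1` and it differs from compound 2 at one place, with isopentyl in place of phenyl on an aromatic carbon of the five-membered aromatic ring with 3 nitrogen. Among the measured compounds shown here, the counted difference is isopentyl in place of phenyl on an aromatic carbon and no measured step is available to size it. Compound 1 carries isopentyl as well and reads > 20000 nM as a limit, so that group shows no activity in the one case at hand. The expected step of an at least 1.1-fold lower number from compound 2 to compound 3 (0.04 log units; that floor lies within the scatter) is small, with at most a modest gain. Compound 3 is estimated at 18000 nM in this assay with an expected range from 6000 nM to 40000 nM and a good chance of another limit.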

Compound 3, half-maximal inhibitory concentration: > 20000 nM
Compound 3: a limit, no number; the forecaster's own chance of this, stated with the estimate: 60%; at least 1.1-fold (0.04 log units) between middle value and limit.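

Among the compounds shown here, compound 3 gives only a limit of the assay, so the steps to it from compound 1 and from compound 2 cannot be read, and no new step comes from this result. The compounds shown leave open whether either change alters potency in this assay, since all readings rest on one value: the limit of > 20000 nM in this assay, at which 3 of the 3 values shown sit.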